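Phenoxy for benzylamino on the shared core

A few compounds are considered here, and "the series" means these few. Any claim that something is new, unique, unknown or untested is made for them only; others in the source may bear on it.

Compound 3 `Nc1cc(N)c2nc(-c3ccccc3)c(NCc3ccc(F)cc3)nc2c1` carries the (4-fluorobenzyl)amino group on the shared core. In a functional assay on SK-MEL-5 cells (Homo sapiens) for inhibition, read by sulforhodamine B assay, with a stated time of 48 h (a higher number here means a weaker inhibitor of growth, a lower number a stronger inhibitor of growth), compound 3 gives 1860 nM, the lowest of the three numbers recorded. Compound 1 `Nc1cc(N)c2nc(-c3ccccc3)c(Oc3ccc(Cl)c(Cl)c3)nc2c1` gives 9770 nM, and compound 2 `COc1ccc(CNc2nc3cc(N)cc(N)c3nc2-c2ccccc2)cc1OC` gives 10000 nM. Both steps to compound 3 are beyond the scatter: a 5.3-fold lower number from compound 1 to compound 3 (0.72 log units; beyond the scatter) and a 5.4-fold lower number from compound 2 to compound 3 (0.73 log units; beyond the scatter).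

Compound 4 `Nc1cc(N)c2nc(-c3ccccc3)c(Oc3ccc(F)cc3)nc2c1` differs from compound 3 by 4-fluorophenoxy in place of (4-fluorobenzyl)amino on an aromatic carbon. For the measured compounds named here, no measured pair isolates this exchange of the linking nitrogen for oxygen with the same aryl group. The nearest guide is compound 1, whose phenoxy-linked aryl gives the higher number seen in a 5.3-fold lower number from compound 1 to compound 3 (0.72 log units; beyond the scatter), though its aryl substituents also differ. The step of a 5.4-fold lower number from compound 2 to compound 3 (0.73 log units; beyond the scatter) shows that the aryl substituents alone can move the number by a similar amount, so the linker share is not separable.

On this basis compound 4 is expected to give a higher number than compound 3, with the step of a 2.7-fold higher number from compound 3 to compound 4 (0.43 log units; beyond the scatter) estimated as modest. The estimate for compound 4 in this assay is 5000 nM, within 1500 nM to 15000 nM.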

Compound 4, concentration for 50% growth inhibition: 12300 nM
The estimate for compound 4 lay 2.5-fold (0.39 log units) below the measured number; the range from low to high includes it.
By their numbers in this assay, from the lowest: compound 3; then compounds 1, 2 and 4 (each within the scatter of the next).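

For the compounds shown here, with a fluorinated aryl group on both sides, this assay shows a 6.6-fold higher number from compound 3 to compound 4 (0.82 log units; beyond the scatter) as the first reading of 4-fluorophenoxy against (4-fluorobenzyl)amino at this position, so the change of linking group counts here without the change from 3,4-dichloro substitution. Among the phenoxy-linked compounds, the step of a 1.3-fold higher number from compound 1 to compound 4 (0.10 log units; within the scatter) leaves the exchange of 3,4-dichlorophenyl for 4-fluorophenyl without a readable effect, whereas the benzylamino pair gave a 5.4-fold lower number from compound 2 to compound 3 (0.73 log units; beyond the scatter) on changing its aryl group. No measurement on hand explains the difference between the linking groups.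

The step from compound 3 to compound 4 changes both the linking atom and the chain carbon, so the share of each stays unresolved. A (4-fluorophenyl)amino or 4-fluorobenzyloxy group at this position would separate the two.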